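The source may report more compounds than this note shows. Statements on the series, on what has been measured and on what is new or still open speak of the compounds shown alone.

Compound 1 `O=C(NCCCCc1ccccc1)c1cccc(C2OCC(=O)N2c2cccc(F)c2)c1`: 87%
Compound 2 `CCOc1ccccc1N1C(=O)C(C)SC1c1cccc(C(=O)NCCCCc2ccccc2)c1`: 94%

In a functional assay on HOS-TE85 cells (Homo sapiens) for inhibition, read by CCK-8 assay, with a stated time of 72 h, tested at 1 uM (on this read-out higher numbers stand for more inhibition at the one concentration tested (going by the name of the read-out) and lower numbers for less inhibition), compound 2 gives 94%, the higher of the two numbers, while compound 1 gives 87%, a gap that lies within the usual scatter, so the two cannot be ranked. Compound 3 `COc1ccccc1N1C(=O)C(C)SC1c1cccc(C(=O)NCCCCc2ccccc2)c1` is not yet measured. It differs from compound 2 by one small change: hydrogen in place of methyl on a saturated chain carbon bound to an oxygen on an aromatic ring, ethoxy becoming methoxy. Among the compounds with values here, no measured pair shows what such a change does here. Given how close compound 1 and compound 2 sit, the step of a number 4 percentage points lower from compound 2 to compound 3 (within the scatter) is expected to stay within the scatter. Compound 3 is therefore estimated at 90%, in a range from 75% to 98%.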

Compound 3, a percentage reported as inhibition, at one concentration (the size of the read-out at that concentration, not a potency): 95%
Compound 3: middle estimate off by 5 percentage points, on the low side; low and high end bracket the measured number.
By their numbers in this assay, from the lowest: compounds 1, 2 and 3 (each within the scatter of the next).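

In this assay, within the data shown here, changing ethoxy to methoxy gives a number 1 percentage points higher from compound 2 to compound 3 (within the scatter), the first measured pair for this change. At this position on the 2-ethoxyphenyl group, removing the one methyl therefore produces no difference that can be told from scatter, and the two compounds cannot be ranked. Nothing available offers an explanation for this result. As far as these compounds go, whether a longer chain such as propoxy or butoxy, or a hydroxyl or an amine, would give a higher, lower or level number here remains open. Results at a single concentration also leave open any difference in potency between these compounds.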